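Para-Substituent Exchange on the Benzyl Ether Aryl Ring

The source may hold more compounds than are shown below. What is called first, only, known or untested is meant among the compounds shown, and "the series" means these compounds.

Compound 1 `Cc1cc(C(=O)O)nn1Cc1cc(Br)ccc1OCc1ccc(Cl)cc1` — in an assay on CHO-K1 cells for displacement of a labelled ligand from prostaglandin E2 receptor EP1 subtype (Homo sapiens) (on this read-out lower numbers stand for stronger inhibition and higher numbers for weaker inhibition), compound 1 gives 8.71 nM.
Compound 2 `Cc1cc(C(=O)O)nn1Cc1cc(Br)ccc1OCc1ccc(C(F)(F)F)cc1` — in this assay compound 2 gives 35.5 nM.

Within the data shown here, compound 2 holds the higher of the two numbers measured so far; its only neighbour is compound 1, and the step of a 4.1-fold higher number from compound 1 to compound 2 (0.61 log units; beyond the scatter) is modest yet beyond the scatter. Compound 3 `Cc1cc(C(=O)O)nn1Cc1cc(Br)ccc1OCc1ccc(C(C)(C)C)cc1` is not yet measured. It differs from compound 2 in one place: tert-butyl in place of trifluoromethyl on an aromatic carbon. Among the measured compounds shown here, no measured pair shows this particular exchange, so the only step that bears on it is the one between compound 1 and compound 2, which shows that swapping the group at this position shifts the number by a moderate amount. Replacing trifluoromethyl with tert-butyl, two groups of the same heavy-atom count, is expected to move this assay little, perhaps a slight rise in the number. Compound 3 is therefore estimated at 50 nM, within 15 nM to 180 nM, a step of a 1.4-fold higher number from compound 2 to compound 3 (0.15 log units; within the scatter).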

Compound 3, half-maximal inhibitory concentration: 1230 nM
Beside the measured number, compound 3's estimate is 25-fold (1.39 log units) below it; the measured number lies above the stated range.
By their numbers in this assay, from the lowest: compound 1; then compound 2; then compound 3.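

The exchange shows that heavy-atom count does not settle the outcome at this position: in this assay tert-butyl in place of trifluoromethyl, with the same count and neither group carrying a ring, a charge or a hydrogen-bond donor or acceptor, gives a 35-fold higher number from compound 2 to compound 3 (1.54 log units; beyond the scatter) and not a small shift. Against the chloro group, tert-butyl gives a 140-fold higher number from compound 1 to compound 3 (2.15 log units; beyond the scatter) and so opens a far wider gap than the modest 4.1-fold higher number from compound 1 to compound 2 (0.61 log units; beyond the scatter) that the earlier compounds showed. Nothing available explains why these groups differ so sharply here.

Going by these compounds, it remains open whether a methyl group, a methoxy group or a nitrile at this place would stay near compound 1 or move towards compound 3. On these data alone, it is also open whether the order of chloro, trifluoromethyl and tert-butyl would hold with fluoro in place of the bromo group on the core.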